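This account rests on a few compounds, and the source may have more. Where it says the series, first, only, none or still open, it means among the compounds named here.

Compound 2 `N#CC1=C(N)Oc2c(c3nc4ccccc4nc3c3ccccc23)C12C(=O)N(Cc1cnnn1-c1ccc(Br)cc1)c1ccccc12` carries a 4-bromophenyl on an aromatic nitrogen. Within the data shown here, in a functional assay on MCF7 cells (Homo sapiens) for antiproliferative activity, read by MTT assay, with a stated time of 48 h (a lower number here means a stronger inhibitor, a higher number a weaker inhibitor), compound 2 gives 36600 nM, the only number so far. Compound 1 `N#CC1=C(N)Oc2c(c3nc4ccccc4nc3c3ccccc23)C12C(=O)N(Cc1cnnn1-c1ccccc1Cl)c1ccccc12`, the 2-chlorophenyl analogue, gives only a limit of the assay in this assay, namely > 50000 nM (the limit of > 50000 nM in this assay, at which 1 of the 2 values shown sits). Among the measured compounds shown here, the single measured step, an at least 1.3-fold lower number from compound 1 to compound 2 (0.13 log units; that floor lies within the scatter), therefore shows no change that can be called real. Compound 3 `COc1ccccc1-n1nncc1CN1C(=O)C2(C(C#N)=C(N)Oc3c2c2nc4ccccc4nc2c2ccccc32)c2ccccc21` differs from compound 2 in one place: 2-methoxyphenyl in place of 4-bromophenyl on an aromatic nitrogen. No measured step touches a methoxy group; the only comparison shown, an exchange of one phenyl substituent for another, stayed within the scatter. The step of a 1.2-fold higher number from compound 2 to compound 3 (0.09 log units; within the scatter) is accordingly expected to remain within the scatter. For compound 3 the estimate in this assay is 45000 nM, ranging from 15000 nM to 150000 nM, with a real chance that the assay again reports only a limit.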

Compound 3, half-maximal inhibitory concentration: > 50000 nM
Compound 3 gave a limit, no number; the forecaster's own chance of this, stated with the estimate: 50%; middle value at least 1.1-fold (0.04 log units) away from the limit.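

In this assay, the exchange on the aromatic nitrogen reads as an at least 1.3-fold higher number from compound 2 to compound 3 (0.13 log units; that floor lies within the scatter), so moving from 4-bromophenyl to 2-methoxyphenyl produces no change that can be called real. Compound 3 gives only a limit of the assay, > 50000 nM. The step between compound 1 and compound 3 cannot be read, and a second substituted phenyl now joins the values at this limit, leaving compound 2 as the only one with a number: the limit of > 50000 nM in this assay, at which 2 of the 3 values shown sit.

With a single number in the set, the three phenyl groups cannot be ranked, and no trend can be assigned to this position. As far as these compounds go, whether an amine or a carboxylic acid on this phenyl ring, or a longer chain in place of the ring, would give a clear step from compound 2 remains open.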